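A few compounds are considered here, and "the series" means these few. Any claim that something is new, unique, unknown or untested is made for them only; others in the source may bear on it.

In an ADME assay on microsomes from liver (Rattus norvegicus) for metabolic stability (on this read-out higher numbers stand for fast clearance and lower numbers for slow clearance), compound 1 `CNc1nc(NC2(C#N)CCCCC2)nc(-n2cccn2)n1` with its 1H-pyrazol-1-yl group gives 103 mL/min/kg as its clearance. Compound 2 `CNc1nc(NC2(C#N)CCCCC2)nc(N2CCCC2)n1` with its pyrrolidin-1-yl group gives > 276 mL/min/kg and that is a limit of the assay and not a number. Compound 3 `CNc1nc(NC2(C#N)CCCCC2)nc(OC)n1` with its methoxy group gives 196 mL/min/kg and so stands within the scatter of compound 1. The gap there is a 1.9-fold higher number from compound 1 to compound 3 (0.28 log units; within the scatter) and it does not separate the two. Going by the values given here, the one step clearly past the scatter is an at least 2.6-fold higher number from compound 1 to compound 2 (0.42 log units; beyond the scatter) on the same carbon. The remaining step is an at least 1.4-fold lower number from compound 2 to compound 3 (0.14 log units; that floor lies within the scatter) and it adds little.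

The change to compound 4 `CNc1nc(NC2(C#N)CCCCC2)nc(SC)n1` is methylsulfanyl in place of methoxy on an aromatic carbon and it stays at the same place on the shared core. Among the compounds with values here, no measured step makes this swap, and each measured step has a ring-bearing group on at least one side, so all three bear on it only indirectly. The expectation therefore rests on compound 3 at 196 mL/min/kg as the anchor. The estimated step of a 1.0-fold higher number from compound 3 to compound 4 (0.01 log units; within the scatter) is expected to stay within the scatter in this assay with no firm direction. Compound 4 is estimated at 200 mL/min/kg with an expected range from 110 mL/min/kg to 276 mL/min/kg in this read-out.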

Compound 4, clearance: 579 mL/min/kg
For compound 4 the middle estimate is 2.9-fold (0.46 log units) below the measured one; the whole stated range lies below it.
By their numbers in this assay, from the lowest: compounds 1 and 3 (each within the scatter of the next); then compound 4.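

In this assay, this position, on an aromatic carbon between two ring nitrogen atoms, responds to methylsulfanyl in place of methoxy with a 3.0-fold higher number from compound 3 to compound 4 (0.47 log units; beyond the scatter), although the two groups match in every feature counted for them except the exchange of oxygen for sulfur. Against the ring-bearing 1H-pyrazol-1-yl group the gap is a 5.6-fold higher number from compound 1 to compound 4 (0.75 log units; beyond the scatter), so among the groups read as numbers, a small ringless group at this carbon can lie well past compound 1, while methoxy in compound 3 stayed within the scatter of compound 1. The step from compound 2 to compound 4 cannot be read, as compound 2 carries a limit of the assay and not a number: the limit of > 276 mL/min/kg in this assay, at which 1 of the 4 values shown sits.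

It remains open whether the higher number follows the sulfur atom itself or the methylsulfanyl group as a whole, as only one sulfur-bearing group stands among these compounds; a longer chain such as ethylsulfanyl, or a methylsulfonyl group, would bear on this. Going by these compounds, how an open-chain amine such as dimethylamino would read at this carbon also remains open, as does whether the step from methoxy to methylsulfanyl holds with other groups elsewhere on the shared core.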